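Shortening the Sulfanyl Chain on the Quinazoline Amine

The compounds below may be only part of what the source reports. "The series", "measured", "known", "first", "only" and "open" are said of these compounds alone.

Measured compounds:
compound 1 `CSc1ccc(CNc2nc(SC)nc3ncccc23)cc1` — 5350 nM
compound 2 `CCCCCSc1nc(NCc2ccc([Se]C)cc2)c2ccccc2n1` — > 100000 nM

In a functional assay on CCRF-CEM cells (Homo sapiens) for cytotoxicity, read by MTT assay, with a stated time of 72 h (on this read-out higher numbers stand for weaker inhibition of growth and lower numbers for stronger inhibition of growth), compound 1 gives 5350 nM. For compound 2 this assay returns only a limit, > 100000 nM, so its growth inhibition is not pinned to a number; it sits at the limit of > 100000 nM in this assay, at which 1 of the 2 values shown sits. Among the compounds with values here, no step between compound 1 and compound 2 is counted here, since they differ in more than one place, and only their two values stand side by side.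

Compound 3 `CSc1nc(NCc2ccc([Se]C)cc2)c2ccccc2n1` has not yet been tested in this assay. It differs from compound 2 in a single place: hydrogen in place of butyl on a saturated chain carbon bound to a sulfur. Within the data shown here, the methylsulfanyl group of compound 3 mirrors the one present in compound 1, which gives 5350 nM in this assay, while compound 2 with its pentylsulfanyl group reaches only the limit > 100000 nM.

On that basis the step from compound 2 to compound 3 is expected to move toward stronger growth inhibition, by an at least 3.3-fold lower number from compound 2 to compound 3 (0.52 log units; beyond the scatter). Compound 3 is therefore estimated to give 30000 nM in this assay, with a range from 5000 nM to 100000 nM.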

Compound 3, concentration for 50% growth inhibition: 63300 nM
Estimate against measurement, compound 3: 2.1-fold (0.32 log units) below, within the range that was stated.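

In this assay, within the data shown here, the change from pentylsulfanyl to methylsulfanyl gives the first step that can be read at this position: an at least 1.5-fold lower number from compound 2 to compound 3 (0.19 log units; that floor lies within the scatter). Compound 2 stands only at a limit, which is why this step is a floor and not a full size: the limit of > 100000 nM in this assay, at which 1 of the 3 values shown sits. Compound 3 gives an actual number, 63300 nM, so with the short chain on the shared core the growth inhibition can be pinned down. The floor alone does not establish a change beyond the scatter.

The compounds shown leave open how growth inhibition runs along the chain, since an ethyl or propyl group on this sulfur, or an amine in place of the sulfanyl group, would show whether the effect follows chain length or belongs to methyl alone. Compound 1 and compound 3 differ in more than one place, so their values only stand side by side, and what the selenium-bearing group contributes relative to the sulfur-bearing group of compound 1 remains unresolved.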